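Chlorothiophene in Place of Tert-Butyl: an Expected Potency Gain

The source may hold more compounds than are shown below. What is called first, only, known or untested is meant among the compounds shown, and "the series" means these compounds.

Compound 1 `CCOC(=O)c1cnc(C)nc1NN1C(=O)C=C(C)C1=O` gives 16000 nM in this assay.
Compound 2 `CCOC(=O)c1cnc(C(C)(C)C)nc1NN1C(=O)C=C(C)C1=O` gives 1000 nM.
Compound 3 `CCOC(=O)c1cnc(-c2ccc(C)s2)nc1NN1C(=O)C=C(C)C1=O` gives 200 nM.

In a functional assay on Jurkat cells for inhibition of nuclear factor NF-kappa-B complex (Homo sapiens) (a lower number here means a stronger inhibitor, a higher number a weaker inhibitor), compound 2 holds the second highest of the three numbers: its nearest neighbour is compound 3, reached by a 5.0-fold lower number from compound 2 to compound 3 (0.70 log units; beyond the scatter), and its furthest is compound 1, from which a 16-fold lower number from compound 1 to compound 2 (1.20 log units; beyond the scatter). Compound 4 `CCOC(=O)c1cnc(-c2ccc(Cl)s2)nc1NN1C(=O)C=C(C)C1=O` differs from compound 2 by 5-chlorothiophen-2-yl in place of tert-butyl on an aromatic carbon. The step that bears directly on this change is a 5.0-fold lower number from compound 2 to compound 3 (0.70 log units; beyond the scatter), where 5-methylthiophen-2-yl took the place of tert-butyl; an 80-fold lower number from compound 1 to compound 3 (1.90 log units; beyond the scatter) shows the same ring group against methyl. A 5-chlorothiophen-2-yl group is therefore expected to give a modest step to a lower number, a 4.0-fold lower number from compound 2 to compound 4 (0.60 log units; beyond the scatter). Compound 4 is estimated at 250 nM, with a range from 80 nM to 800 nM.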

Compound 4, half-maximal inhibitory concentration: 300 nM
Beside the measured number, compound 4's estimate is 1.2-fold (0.08 log units) below it; measured number inside the range.
By their numbers in this assay, from the lowest: compounds 3 and 4 (each within the scatter of the next); then compound 2; then compound 1.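

The aromatic carbon between two ring nitrogen atoms accepts a second substituted thiophene, which keeps the advantage over the smaller groups, with a 3.3-fold lower number from compound 2 to compound 4 (0.52 log units; beyond the scatter) and a 53-fold lower number from compound 1 to compound 4 (1.73 log units; beyond the scatter) in this assay. On the thiophene itself, chloro and methyl cannot be told apart, with a 1.5-fold higher number from compound 3 to compound 4 (0.18 log units; within the scatter), so this change shows no clear effect. Nothing available explains the advantage of either thiophene over tert-butyl. On these data alone, what a phenyl ring, an unsubstituted thiophen-2-yl or an amine at this carbon would give remains open.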